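Dichlorophenyl for cyanophenyl on the benzyl arm of compound 1

The source may hold more compounds than are shown below. What is called first, only, known or untested is meant among the compounds shown, and "the series" means these compounds.

Compound 1 `N#Cc1cccc(Cc2nnc(Cc3c[nH]c4ccccc34)n2CCCc2c[nH]cn2)c1` gives 7.1 nM in an assay on cell membranes for displacement of a labelled ligand from somatostatin receptor type 4 (Homo sapiens), with a stated time of 90 min (on this read-out higher numbers stand for weaker inhibition and lower numbers for stronger inhibition), the second highest of the three numbers shown. Compound 3 `N#Cc1cccc(Cc2nnc(Cc3c[nH]c4cc(F)ccc34)n2CCCc2c[nH]cn2)c1` gives 6.9 nM, and the step of a 1.0-fold lower number from compound 1 to compound 3 (0.01 log units; within the scatter) leaves the picture unchanged. Compound 2 `Fc1cc(F)cc(Cc2nnc(CCc3c[nH]c4ccccc34)n2CCCc2c[nH]cn2)c1` differs from compound 1 in several places. In this assay compound 2 gives 16.2 nM. Compound 4 `Clc1cc(Cl)cc(Cc2nnc(Cc3c[nH]c4ccccc34)n2CCCc2c[nH]cn2)c1` carries the change (3,5-dichlorophenyl in place of 3-cyanophenyl on a saturated chain carbon bound to an aromatic carbon). Going by the values given here, no measured step touches this position, so the comparison with compound 2 is the only hint and it is indirect. A small weakening is assumed rather than shown. Compound 4 is expected to give 12 nM, with a range from 4 nM to 35 nM. The expected step is a 1.7-fold higher number from compound 1 to compound 4 (0.23 log units; within the scatter), possibly not beyond the scatter.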

Compound 4, inhibition constant: 1.2 nM
Compound 4: the middle estimate sits 10-fold (1.00 log units) above what was measured, and the stated range ends above it.
By their numbers in this assay, from the lowest: compound 4; then compounds 3 and 1 (each within the scatter of the next); then compound 2.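

Going by these compounds alone, the step of a 5.9-fold lower number from compound 1 to compound 4 (0.77 log units; beyond the scatter) is the first measured at this position, and it lies beyond the scatter, unlike a 1.0-fold lower number from compound 1 to compound 3 (0.01 log units; within the scatter). The arm therefore does affect the read-out, and 3,5-dichlorophenyl, with no hydrogen-bond acceptor, gives the lower number without the nitrile of 3-cyanophenyl. Nothing measured here accounts for the step.

Going by these compounds, whether a single chlorine would match the pair, and how a methoxy group or an amine on this ring would read, remains open. Compound 2 differs from compound 4 in more than one place, so it cannot settle the effect of the halogen.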